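This account rests on a few compounds, and the source may have more. Where it says the series, first, only, none or still open, it means among the compounds named here.

Compound 2 `COc1cccc(CNCCCNc2ccnc3cc(-c4ccc(C(C)(C)C)cc4)ccc23)c1O` gives 32000 nM in a physicochemical assay for solubility, with a stated time of 18 h, at pH 7.4 (a higher number here means a more soluble compound, a lower number a less soluble compound), level with compound 3 `CC(C)(C)c1ccc(-c2ccc3c(NCCCNCc4ccco4)ccnc3c2)cc1`, which gives 32000 nM; compound 1 `COc1ccc(F)cc1CNCCCNc1ccnc2cc(Oc3ccc(F)cc3)ccc12` sits lower, at 14500 nM. For the measured compounds named here, the one measured single-point step, no change at the digits printed from compound 2 to compound 3 (within the scatter), concerns the other end of the shared chain. Compound 4 `COc1cccc(CNCCCNc2ccnc3cc(-c4ccccc4)ccc23)c1O` differs from compound 2 by hydrogen in place of tert-butyl on an aromatic carbon. Going by the values given here, no measured step touches this position; compound 1 differs from the others in several places at once and cannot isolate it. Without such a step, the change is expected to leave the number near that of compound 2, and the step from compound 2 to compound 4 is expected as a 1.3-fold higher number from compound 2 to compound 4 (0.10 log units; within the scatter). Compound 4 is therefore expected to give about 40000 nM, between 16000 nM and 100000 nM.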

Compound 4, solubility: 32000 nM
Beside the measured number, compound 4's estimate is 1.3-fold (0.10 log units) above it; the measured number falls inside the stated range.
By their numbers in this assay, from the lowest: compound 1; then compounds 2, 3 and 4 (each within the scatter of the next).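

For the compounds shown here, at this position, in this assay, hydrogen in place of tert-butyl on an aromatic carbon gives no change at the digits printed from compound 2 to compound 4 (within the scatter), the first single-change reading here. Taking away the 4 heavy atoms of tert-butyl therefore leaves the number within the scatter, as the change at the other end of the shared chain also did. The compounds shown offer no evidence that accounts for this.

On these data alone, whether an amine or a carboxylic acid at this position would shift the number remains open. Also open, as far as these compounds go, is whether the 4-(tert-butyl)phenyl to phenyl change would read the same with furan-2-yl at the other end of the chain.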